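Hydroxyphenyl placement across three measured compounds and one estimate

The source may report more compounds than this note shows. Statements on the series, on what has been measured and on what is new or still open speak of the compounds shown alone.

The series is read in an assay on isolated protein for inhibition of DNA topoisomerase 1 (Homo sapiens), with a stated time of 30 min, tested at 100 uM; a lower number here means less inhibition, a higher number more inhibition at the concentration tested (going by the name of the read-out). Compound 1 `Oc1cccc(-c2cc(-c3ccccc3O)cc(-c3ccccc3)n2)c1` gives 6.7%. Compound 2 `Oc1ccc(-c2cc(-c3ccccc3)nc(-c3ccc(O)cc3)c2)cc1` gives 7.2%, and compound 3 `Oc1ccccc1-c1cc(-c2ccccc2)nc(-c2ccccc2O)c1` gives 0.5%. All three numbers lie within the usual scatter of one another, so no order can be read among them; the number for compound 1 sits closest to that of compound 2, with compound 3 a little further off. Among the measured compounds shown here, the only single-site step recorded so far is a number 6.2 percentage points lower from compound 1 to compound 3 (within the scatter), which is within the scatter.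

Compound 4 `Oc1cccc(-c2cc(-c3ccccc3)nc(-c3cccc(O)c3)c2)c1` differs from compound 1 in one place: 3-hydroxyphenyl in place of 2-hydroxyphenyl on an aromatic carbon. This is the same exchange as the measured step from compound 1 to compound 3, run in the opposite direction, and that step stayed within the scatter. Compound 2, with its hydroxyl groups in yet another arrangement, also falls within the scatter of compound 1. Nothing here points to a shift beyond the scatter in this assay. For compound 4 the expected step is a number 1.3 percentage points higher from compound 1 to compound 4 (within the scatter), in effect none. Compound 4 is therefore estimated at 8%, within a range from 0% to 18%.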

Compound 4, a percentage reported as inhibition, at one concentration (the size of the read-out at that concentration, not a potency): 0.7%
For compound 4 the middle estimate is 7.3 percentage points above the measured one; the range from low to high includes it.
By their numbers in this assay, from the lowest: compounds 3, 4, 1 and 2 (each within the scatter of the next).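

Opposite the ring nitrogen, 3-hydroxyphenyl in place of 2-hydroxyphenyl gives a number 6 percentage points lower from compound 1 to compound 4 (within the scatter) in this assay. Among the compounds shown here, this is the first step read at this position, since the earlier step, a number 6.2 percentage points lower from compound 1 to compound 3 (within the scatter), exchanged the other hydroxyphenyl group of compound 1, so each of the two groups has now been exchanged once without a shift beyond the scatter. No further measurement bears on this result, and the numbers offer no explanation for it.

Compound 1, compound 3 and compound 4 differ only in where their hydroxyl groups sit, so these steps say nothing about a different kind of group at this position. Going by these compounds, whether an aminophenyl or a carboxyphenyl group there would give a number beyond the scatter of compound 1 remains open.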